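Replacing One Amide Substituent With Another

The source may report more compounds than this note shows. Statements on the series, on what has been measured and on what is new or still open speak of the compounds shown alone.

Of the compounds shown here, three built on a shared core have been tested in a functional assay on KBVIN cells (Homo sapiens) for antiproliferative activity, read by sulforhodamine B assay, with a stated time of 3 days; a lower number here means a stronger inhibitor of growth, a higher number a weaker inhibitor of growth. Compound 1 `O=C(NCCO)c1cccc(Nc2ncc(F)c(Nc3ccc(F)cc3)n2)c1` gives 21400 nM. Compound 2 `Cn1ccnc1NC(=O)c1cccc(Nc2ncc(F)c(Nc3ccc(F)cc3)n2)c1` gives 13100 nM. Compound 3 `COc1ccc(N2CCN(C)CC2)cc1Nc1ncc(F)c(Nc2ccc(F)cc2)n1`, which carries a different set of groups in place of the amide, gives 910 nM. Among these three numbers compound 2 holds the second highest: its nearest neighbour is compound 1, and the gap to compound 3 is the largest, lying beyond the scatter.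

Among the compounds with values here, the one single-point step measured so far, a 1.6-fold lower number from compound 1 to compound 2 (0.21 log units; within the scatter), exchanged the group on the amide-type nitrogen and left the number within the scatter.

Compound 4 `O=C(Nc1ccccn1)c1cccc(Nc2ncc(F)c(Nc3ccc(F)cc3)n2)c1` has not yet been measured. It differs from compound 2 at the same place: pyridin-2-yl in place of 1-methyl-1H-imidazol-2-yl on an amide-type nitrogen. The measured step that bears on this is the exchange at the amide-type nitrogen from compound 1 to compound 2, which stayed within the scatter, so the expectation for compound 4 in this assay is a number close to that of compound 2, with no step beyond the scatter in either direction. Compound 4 is therefore estimated at about 13000 nM, with a range from 5000 nM to 35000 nM. This estimate corresponds to an expected step of a 1.0-fold lower number from compound 2 to compound 4 (0.00 log units; within the scatter).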

Compound 4, concentration for 50% growth inhibition: 13700 nM
The estimate for compound 4 lay 1.1-fold (0.02 log units) below the measured number; low and high end bracket the measured number.
By their numbers in this assay, from the lowest: compound 3; then compounds 2, 4 and 1 (each within the scatter of the next).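

In this assay, a second exchange on the amide-type nitrogen, pyridin-2-yl in place of 1-methyl-1H-imidazol-2-yl, gives a 1.0-fold higher number from compound 2 to compound 4 (0.02 log units; within the scatter), so trading a five-membered aromatic ring with 2 hetero atoms for a six-membered aromatic ring with 1 hetero atom leaves the number within the scatter. Pyridin-2-yl in place of the open chain 2-hydroxyethyl gives a 1.6-fold lower number from compound 1 to compound 4 (0.19 log units; within the scatter), so all three groups seen at this position, one chain and two aromatic rings, now lie within the scatter of one another, a closer view of this position than the single step available before. No measurement shown here offers a reason for this result.

The compounds shown leave open whether any other kind of group on this nitrogen, such as a plain phenyl ring, a chain ending in a carboxylic acid or a longer chain ending in an amine, would move the number beyond the scatter. Compound 3, at 910 nM, differs from these amides in more than one place, so its value cannot be tied to any single group.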